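The compounds below may be only part of what the source reports. "The series", "measured", "known", "first", "only" and "open" are said of these compounds alone.

Of the compounds shown here, two sharing one core have been measured so far. Compound 1 `O=c1cc(-c2ccccc2)oc2cc(N3COc4c(cccc4[N+](=O)[O-])C3)ccc12` carries a nitro group on an aromatic carbon, and in a functional assay on MCF7 cells (Homo sapiens) for inhibition, read by MTT assay, with a stated time of 48 h, tested at 30 ug/mL (on this read-out lower numbers stand for less inhibition of growth and higher numbers for more inhibition of growth at the one concentration tested), compound 1 gives 5.65%. Compound 2 `O=c1cc(-c2ccccc2)oc2cc(N3COc4c(Br)cccc4C3)ccc12` carries a bromo group at that position, and in this assay compound 2 gives 7.89%. The change from nitro to bromo gives a number 2.2 percentage points higher from compound 1 to compound 2 (within the scatter), so the two numbers do not differ beyond the scatter, and compound 2 cannot be set apart from compound 1 on these data; both sit near the bottom of the scale, meaning little inhibition of growth.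

Compound 3 `Cc1cccc2c1OCN(c1ccc3c(=O)cc(-c4ccccc4)oc3c1)C2` is not yet measured. It differs from compound 2 in one place: methyl in place of bromo on an aromatic carbon. For the measured compounds named here, only one measured step touches this position, the nitro-to-bromo change a number 2.2 percentage points higher from compound 1 to compound 2 (within the scatter), and it stayed within the scatter. Nothing here points to a move in either direction, so the expected step in this assay is a number 0.9 percentage points lower from compound 2 to compound 3 (within the scatter), none beyond the scatter. The estimate for compound 3 in this assay is therefore 7%, with a likely range from 0% to 18%.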

Compound 3, percent growth inhibition at one concentration: 57.8%
Estimate against measurement, compound 3: 50.8 percentage points below; measured number above the stated range.
By their numbers in this assay, from the lowest: compounds 1 and 2 (each within the scatter of the next); then compound 3.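

In this assay methyl in place of bromo gives a number 49.9 percentage points higher from compound 2 to compound 3 (beyond the scatter) and methyl in place of nitro gives a number 52.2 percentage points higher from compound 1 to compound 3 (beyond the scatter) so this position on the shared core can matter a great deal in this read-out. The earlier pair showed only that nitro and bromo could not be told apart; it said nothing about the position as a whole, and methyl now stands clearly apart from both groups. The change from bromo to methyl is also a small one on paper, with one heavy atom replacing one heavy atom and no hydrogen-bond donors, hydrogen-bond acceptors or net charge on either side, yet no measurement here explains why methyl behaves differently.

From the compounds shown here alone, it remains open whether an ethyl group, a methoxy group or an amine at this position would give a number close to that of compound 3 or fall back towards those of compound 1 and compound 2. With a single tested concentration, these numbers also leave open how the compounds would compare across a range of concentrations.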